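The source may hold more compounds than are shown below. What is called first, only, known or untested is meant among the compounds shown, and "the series" means these compounds.

In a functional assay on A549 cells (Homo sapiens) for antiproliferative activity, read by sulforhodamine B assay, with a stated time of 3 days; on this read-out higher numbers stand for weaker inhibition of growth and lower numbers for stronger inhibition of growth:
- Compound 1 `O=C(Nc1ccccn1)c1cccc(Nc2ncc(F)c(Nc3ccc(F)cc3)n2)c1`: 15300 nM
- Compound 2 `O=C(Nc1cccc(Nc2ncc(F)c(Nc3ccc(F)cc3)n2)c1)c1ccncc1`: 1650 nM

For the measured compounds named here, compound 2 has the lower of these two numbers, and the only measured step is a 9.3-fold lower number from compound 1 to compound 2 (0.97 log units; beyond the scatter). Compound 3 `O=C(Nc1cccc(Nc2ncc(F)c(Nc3ccc(F)cc3)n2)c1)c1ccccc1` carries phenyl in place of pyridin-4-yl on a carbonyl carbon. The measured step bears on this only loosely, as it replaced (pyridin-2-yl)carbamoyl with ((pyridin-4-yl)carbonyl)amino, not pyridin-4-yl with phenyl. Going by the values given here, with no direct precedent, a small step to a slightly higher number in this assay is expected, possibly none beyond the scatter. The expected change is a 1.5-fold higher number from compound 2 to compound 3 (0.18 log units; within the scatter). For compound 3 the estimated value is 2500 nM, with an expected range of 700 nM to 9000 nM.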

Compound 3, concentration for 50% growth inhibition: 37800 nM
Compound 3: the middle estimate sits 15-fold (1.18 log units) below what was measured; measured number above the stated range.
By their numbers in this assay, from the lowest: compound 2; then compound 1; then compound 3.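

In this assay the ring on the carbonyl carbon turns out to matter greatly: with phenyl in place of pyridin-4-yl there is a 23-fold higher number from compound 2 to compound 3 (1.36 log units; beyond the scatter) and the only difference is the ring nitrogen exchanged for carbon. Benzamido in place of (pyridin-2-yl)carbamoyl gives a 2.5-fold higher number from compound 1 to compound 3 (0.39 log units; beyond the scatter) so compound 3 has the highest number of the three. No measurement here accounts for the effect of this exchange.

Still open, on these data alone, is whether pyridin-3-yl on the same carbonyl carbon would keep the lower number of compound 2, and whether a phenyl ring carrying an amine would restore it.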